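Benzyl-triazole chromone ethers: cytotoxicity toward a nitrile analogue

The compounds below may be only part of what the source reports. "The series", "measured", "known", "first", "only" and "open" are said of these compounds alone.

In an ADME assay on L02 cells (Homo sapiens) for cytotoxicity, read by MTT assay, with a stated time of 48 h (a higher number here means a weaker inhibitor, a lower number a stronger inhibitor), compound 3 `O=c1ccoc2cc(OCc3cn(Cc4ccccc4Br)nn3)ccc12` gives > 300000 nM, a limit of the assay and not a number. Compound 1 `Cc1cccc(Cn2cc(COc3ccc4c(=O)ccoc4c3)nn2)c1` also returns only a limit, > 300000 nM, in this assay. Compound 2 `O=c1ccoc2cc(OCc3cn(Cc4ccc([N+](=O)[O-])cc4)nn3)ccc12` likewise sits at a limit, > 300000 nM. Because all three values sit at the limit of > 300000 nM in this assay, at which 3 of the 3 values shown sit, the steps a step that the two limits leave unreadable from compound 1 to compound 2, a step that the two limits leave unreadable from compound 1 to compound 3 and a step that the two limits leave unreadable from compound 2 to compound 3 cannot be sized. Compound 4 `N#Cc1cccc(Cn2cc(COc3ccc4c(=O)ccoc4c3)nn2)c1` differs from compound 3 by 3-cyanophenyl in place of 2-bromophenyl on a saturated chain carbon bound to an aromatic nitrogen. Each measured exchange of the group on the saturated chain carbon bound to an aromatic nitrogen has left the value at the limit, so no readable step is expected for a number no higher from compound 3 to compound 4 (the limit leaves the size open). Compound 4 is therefore expected to return only a limit as well, estimated at 300000 nM, within 150000 nM to 1000000 nM.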

Compound 4, half-maximal inhibitory concentration: > 300000 nM
Compound 4 was reported as a limit; the forecaster's own chance of this, stated with the estimate: 85%; the middle value lies on the limit itself.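

Compound 4, like compound 1, compound 2 and compound 3, returns only a limit in this assay, so no step to compound 4 can be read: the limit of > 300000 nM in this assay, at which 4 of the 4 values shown sit.

The compounds shown leave open whether any exchange of the group on the saturated chain carbon bound to an aromatic nitrogen changes the value at all.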